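Methoxymethyl for propyl on a triazolopyrimidine-like thiol and hydroxy series

The source may hold more compounds than are shown below. What is called first, only, known or untested is meant among the compounds shown, and "the series" means these compounds.

Compound 1 `COCc1ncc2cnnc(S)n12`: > 48000 nM, a limit of the assay.
Compound 2 `CCCc1ncc2cnnc(S)n12`: > 48000 nM, a limit of the assay.
Compound 3 `CCCc1nc(Br)c2c(Br)nnc(O)n12`: 48000 nM.

Among the compounds with values here, in a functional assay for inhibition, with Homo sapiens as the target (on this read-out lower numbers stand for stronger inhibition and higher numbers for weaker inhibition), compound 3 gives 48000 nM, the only number among the three. The step that the two limits leave unreadable from compound 2 to compound 1 is the change (methoxy in place of ethyl on a saturated chain carbon bound to an aromatic carbon); its size cannot be read due to the limit of > 48000 nM in this assay, at which 2 of the 3 values shown sit. How the core of compound 3 differs from that of compound 2 is not broken down here. Compound 4 `COCc1nc(Br)c2c(Br)nnc(O)n12` differs from compound 3 by methoxy in place of ethyl on a saturated chain carbon bound to an aromatic carbon, the same change made from compound 2 to compound 1. For compound 4 the step of a 1.3-fold higher number from compound 3 to compound 4 (0.10 log units; within the scatter) is expected to be small, resting on compound 3 at 48000 nM and on the unreadable step that the two limits leave unreadable from compound 2 to compound 1. Compound 4 is therefore estimated at 60000 nM, between 24000 nM and 150000 nM.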

Compound 4, half-maximal inhibitory concentration: > 48000 nM
Compound 4: no number, only a limit; the forecaster's own chance of this, stated with the estimate: 60%; the middle value lies beyond the limit too.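

In this assay compound 4 gives > 48000 nM, which is a limit of the assay and not a number. On the core of compound 3, methoxy in place of ethyl gives a number no lower from compound 3 to compound 4 (the limit leaves the size open), so the change shows no gain there, while the matching step from compound 2 to compound 1 cannot be read at all. This does not show that the change behaves alike on both cores, since neither size can be compared, due to a shared ceiling: the limit of > 48000 nM in this assay, at which 3 of the 4 values shown sit.

Going by these compounds, whether an amine or a carboxylic acid in place of the methoxy would give a readable number on either core stays open. The same holds for a chain longer than propyl.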